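Swapping a Bicyclic Amine for Piperidine on the Core

The source may report more compounds than this note shows. Statements on the series, on what has been measured and on what is new or still open speak of the compounds shown alone.

Three compounds have been measured in an ADME assay on a cell-free system (plasma, Rattus norvegicus); a higher number here means a larger unbound share of the compound, a lower number a smaller unbound share:

compound 1, `CC(=O)Nc1cc(-c2cnc(N(C)C(=O)c3c(F)cccc3Cl)c(N3CC4CC4C3)c2)n(C(C)C)n1`, gives 0.022
compound 2, `CC(=O)Nc1cc(-c2ccc(N(C)C(=O)c3c(F)cccc3Cl)c(N3CCCCC3)c2)n(C(C)C)n1`, gives 0.001
compound 3, `CC(=O)Nc1cc(-c2ccc(N(C)C(=O)c3c(F)cccc3Cl)c(N3CC4CC4C3)c2)n(C2CCC2)n1`, gives 0.0004

Among these three numbers compound 1 stands highest in this assay; its nearest neighbour is compound 2, whose number is lower by an amount beyond the usual scatter, and compound 3 lies furthest away, also beyond the scatter. Within the data shown here, compounds 2 and 3 share one core and compound 1 another, so no pair of measured compounds differs in only one place and no single step can be read directly from the data.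

Compound 4, `CC(=O)Nc1cc(-c2cnc(N(C)C(=O)c3c(F)cccc3Cl)c(N3CCCCC3)c2)n(C(C)C)n1`, is compound 1 with one change: a group of 6 heavy atoms (5 carbon, 1 nitrogen; one six-membered non-aromatic ring with 1 hetero atom) in place of a group of 6 heavy atoms (5 carbon, 1 nitrogen; one three-membered non-aromatic ring of carbon only, one five-membered non-aromatic ring with 1 hetero atom), on an aromatic carbon. The same piperidin-1-yl group is present in compound 2, whose core however differs from that of compound 1, so the data do not isolate what this exchange alone does. Among the measured compounds shown here, both measured compounds with the alternative core sit well below compound 1, and the only compound bearing piperidin-1-yl, compound 2, is one of them. On this basis a modest downward step is expected, a 1.8-fold lower number from compound 1 to compound 4 (0.26 log units; within the scatter), though it may not exceed the scatter. Compound 4 is therefore estimated at 0.012 in this assay, with a range from 0.003 to 0.03.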

Compound 4, unbound fraction in the plasma assay: 0.013
Compound 4: middle estimate off by 1.1-fold (0.03 log units), on the low side; measured number inside the range.
By their numbers in the plasma assay, from the lowest: compound 3; then compound 2; then compounds 4 and 1 (each within the scatter of the next).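

Among these compounds, compound 4 allows the exchange of the bicyclic amine for piperidin-1-yl, on an aromatic carbon of a six-membered aromatic ring with 1 nitrogen, to be read on its own for the first time: in the plasma assay the result is a 1.7-fold lower number from compound 1 to compound 4 (0.23 log units; within the scatter), and in a physicochemical assay for solubility, measured as kinetic solubility (a higher number here means a more soluble compound, a lower number a less soluble compound), compound 1 gives 48 ug/mL and compound 4 gives 37.4 ug/mL so that the step is a 1.3-fold lower number from compound 1 to compound 4 (0.11 log units; within the scatter). On the core of compound 1, then, neither read-out tells the two groups apart, although one holds a three-membered ring fused to a five-membered ring and the other a single six-membered ring. Piperidin-1-yl alone also does not bring the very low number seen earlier, since in the plasma assay compound 2 gives 0.001 while compound 4, with the same group on the other core, gives 0.013.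

No measurement at hand offers a reason for these results. Still open, from the compounds shown here alone, is whether a ring containing oxygen, such as morpholin-4-yl, or an open-chain dimethylamino group at this position would shift either number, and whether the bicyclic amine and piperidin-1-yl would also match on the core of compound 2.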